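The compounds below may be only part of what the source reports. "The series", "measured", "known", "first", "only" and "open" are said of these compounds alone.

Compound 1 `COc1ccc(C2N=C(SCc3ccccc3Cl)NC(C)=C2C(=O)Nc2ccc(F)cc2)cc1OC` gave 30.3%. Compound 2 `CC1=C(C(=O)Nc2ccc(F)cc2)C(c2ccc([N+](=O)[O-])cc2)N=C(SCc2ccccc2)N1` gave 32.3%. Compound 3 `CC1=C(C(=O)Nc2ccc(F)cc2)C(c2ccc([N+](=O)[O-])cc2)N=C(SCc2ccccc2Cl)N1` gave 15.9%.

In a functional assay on the whole organism (artery, strain albino) with Rattus norvegicus as the target, with a stated time of 240 min, at a dose of 10 mg/kg by the oral route (a lower number here means less inhibition, a higher number more inhibition at the dose given (going by the name of the read-out)), compound 3 stands lowest of the three numbers, with compound 1 nearest and compound 2 furthest. Both measured steps lead to it: a number 14.4 percentage points lower from compound 1 to compound 3 (beyond the scatter) and a number 16.4 percentage points lower from compound 2 to compound 3 (beyond the scatter), each beyond the scatter. Compound 4 `CC1=C(C(=O)Nc2ccc(F)cc2)C(c2ccc([N+](=O)[O-])cc2)N=C(SCc2ccc(Cl)cc2)N1` differs from compound 3 by 4-chlorophenyl in place of 2-chlorophenyl on a saturated chain carbon bound to a sulfur. Among the compounds with values here, neither measured step moves a chloro from one position to another on this ring; the step of a number 16.4 percentage points lower from compound 2 to compound 3 (beyond the scatter) shows only what appending chloro did, so no measured step bears directly on the change. Compound 4 is therefore expected to stay near compound 3, with a step of a number 3.1 percentage points higher from compound 3 to compound 4 (within the scatter) within the scatter. The estimated value of compound 4 is 19%, between 6% and 34%.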

Compound 4, a percentage reported as inhibition, in the whole organism at one dose (the size of the read-out at that dose, not a potency): 33.3%
Compound 4: the middle estimate sits 14.3 percentage points below what was measured; the range from low to high includes it.
By their numbers in this assay, from the lowest: compound 3; then compounds 1, 2 and 4 (each within the scatter of the next).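

In this assay, where the chloro sits proves to matter: 4-chlorophenyl in place of 2-chlorophenyl on a saturated chain carbon bound to a sulfur gives a number 17.4 percentage points higher from compound 3 to compound 4 (beyond the scatter). Appending chloro in the 4-chlorophenyl form leaves no readable change, with a number 1 percentage points higher from compound 2 to compound 4 (within the scatter). The lower number of compound 3 therefore goes with the 2-chlorophenyl placement and not with chloro in either placement, at least with the 4-nitrophenyl group on the saturated ring carbon.

Nothing measured here explains why the two placements differ. On these data alone, it remains open whether 3-chlorobenzyl or 4-methoxybenzyl on the sulfur would read with compound 3 or with compound 4.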